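The source may hold more compounds than are shown below. What is called first, only, known or untested is meant among the compounds shown, and "the series" means these compounds.

Measured compounds:
Compound 1 `O=C(O)c1ccc(C(=O)/C=C/c2ccc3c(c2)B(O)OC3)cc1`: > 10 ug/mL
Compound 2 `COc1ccccc1C(=O)/C=C/c1ccc2c(c1)B(O)OC2`: 6.35 ug/mL
Compound 3 `COCOc1ccccc1C(=O)/C=C/c1ccc2c(c1)B(O)OC2`: 9.02 ug/mL

All three were tested in an ADME assay on L929 cells (Mus musculus) for cytotoxicity, read by resazurin assay, with a stated time of 72 h; a higher number here means a weaker inhibitor, a lower number a stronger inhibitor. On these data alone, compound 1 stands at the limit of > 10 ug/mL in this assay, at which 1 of the 3 values shown sits, which is a limit of the assay and not a number, so its true position among the measured values is unknown. Among the compounds with values here, compound 2 gives 6.35 ug/mL and compound 3 gives 9.02 ug/mL; the only measured step, a 1.4-fold higher number from compound 2 to compound 3 (0.15 log units; within the scatter), changes a group on a chain hanging from the ring oxygen and lies within the scatter, so these two compounds cannot be ranked against each other.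

Compound 4 `COc1ccc(C(=O)/C=C/c2ccc3c(c2)B(O)OC3)cc1` is not yet measured. It differs from compound 1 by methoxy in place of carboxy on an aromatic carbon. Within the data shown here, no measured step covers an exchange of this kind on the aromatic ring itself, so the only guide is that compound 2, which also carries a methoxy group on its ring, gives a number rather than a limit. Compound 4 is therefore estimated to give about 7.5 ug/mL, with a likely range from 4 ug/mL to 15 ug/mL. Against compound 1 this would mean an expected step of an at least 1.3-fold lower number from compound 1 to compound 4 (0.12 log units; that floor lies within the scatter), whose size cannot be fixed because compound 1 rests at the limit of > 10 ug/mL in this assay, at which 1 of the 3 values shown sits.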

Compound 4, half-maximal inhibitory concentration: > 10 ug/mL
Compound 4: only a limit was reported; the forecaster's own chance of this, stated with the estimate: 35%; at least 1.3-fold (0.12 log units) between middle value and limit.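

In this assay compound 4 gives > 10 ug/mL, which is a limit and not a number. Compound 1 also rests on a limit, so no step can be read between compound 1 and compound 4: the limit of > 10 ug/mL in this assay, at which 2 of the 4 values shown sit.

The compounds shown leave open whether methoxy in place of carboxy on an aromatic carbon changes cytotoxicity at all, and by how much.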